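A few compounds are considered here, and "the series" means these few. Any claim that something is new, unique, unknown or untested is made for them only; others in the source may bear on it.

Among the measured compounds shown here, compound 2 `Cc1cc(O)c(C2=NN(c3ccc(S(N)(=O)=O)cc3)C(/C=C/c3ccccc3)C2)cc1Cl` gives 5520 nM in a functional assay on SK-OV-3 cells (Homo sapiens) for antiproliferative activity, with a stated time of 48 h (on this read-out lower numbers stand for stronger inhibition of growth and higher numbers for weaker inhibition of growth), numerically the higher of the two values known so far; compound 1 `Cc1cc(O)c(C2=NN(c3ccc(S(N)(=O)=O)cc3)C(c3ccccc3O)C2)cc1Cl` gives 4410 nM in this assay, and a 1.3-fold higher number from compound 1 to compound 2 (0.10 log units; within the scatter) lies within the scatter. Compound 3 `COc1ccc(C2CC(c3cc(Cl)c(C)cc3O)=NN2c2ccc(S(N)(=O)=O)cc2)c(OC)c1OC` carries 2,3,4-trimethoxyphenyl in place of 2-phenylethenyl on a saturated ring carbon. For the measured compounds named here, the only measured step that touches this position is the exchange of the group on the same saturated ring carbon, and that step stayed within the scatter. For compound 3 a step of a 1.2-fold lower number from compound 2 to compound 3 (0.09 log units; within the scatter) is therefore expected, not beyond the scatter, giving an estimated 4500 nM with a range from 1500 nM to 14000 nM.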

Compound 3, concentration for 50% growth inhibition: 3710 nM
Estimate against measurement, compound 3: 1.2-fold (0.08 log units) above, within the range that was stated.
By their numbers in this assay, from the lowest: compounds 3, 1 and 2 (each within the scatter of the next).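

In this assay the change to 2,3,4-trimethoxyphenyl on this saturated ring carbon gives a 1.5-fold lower number from compound 2 to compound 3 (0.17 log units; within the scatter) and a 1.2-fold lower number from compound 1 to compound 3 (0.08 log units; within the scatter) and so stays within the scatter against both earlier groups. A group of 12 heavy atoms with 3 hydrogen-bond acceptors therefore shows no readable difference from 2-phenylethenyl, with its 8 heavy atoms and 0 hydrogen-bond acceptors. No measurement at hand offers a reason for this.

On these data alone, whether a methyl group, an amine or a carboxylic acid on this carbon would move the number beyond the scatter stays open. So does the effect of changes elsewhere on the shared core.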